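Sulfonamide aryl variation on a 5-hydroxytryptamine receptor 4 series

A few compounds are considered here, and "the series" means these few. Any claim that something is new, unique, unknown or untested is made for them only; others in the source may bear on it.

Measured compounds:
compound 1 `COc1cc(N)c(Cl)cc1C(=O)CCC1CCN(CCNS(=O)(=O)c2ccc3c(c2)NC(=O)CO3)CC1` gives 6.2 nM
compound 2 `COc1ccc(S(=O)(=O)NCCN2CCC(CCC(=O)c3cc(Cl)c(N)cc3OC)CC2)cc1` gives 12.3 nM

Both values come from an assay on brain for displacement of a labelled ligand from 5-hydroxytryptamine receptor 4 (Cavia porcellus), with a stated time of 30 min, in the presence of a further agent that is not named here; on this read-out lower numbers stand for stronger inhibition and higher numbers for weaker inhibition. Compound 1 holds the lowest of the two numbers; compound 2 sits nearest, and the step of a 2.0-fold higher number from compound 1 to compound 2 (0.30 log units; within the scatter) is within the scatter, so neither compound can be called stronger than the other on these data.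

Compound 3 `COc1cc(N)c(Cl)cc1C(=O)CCC1CCN(CCNS(=O)(=O)c2ccc(NC(C)=O)cc2)CC1` is not yet measured. It differs from compound 1 in that (a group of 10 heavy atoms (8 carbon, 1 nitrogen, 1 oxygen; one six-membered aromatic ring of carbon only) in place of a group of 11 heavy atoms (8 carbon, 1 nitrogen, 2 oxygen; one six-membered non-aromatic ring with 2 hetero atoms, one six-membered aromatic ring of carbon only), on a sulfonyl sulfur). Going by the values given here, the one measured step that bears on this change is the step from compound 1 to compound 2, where a 2.0-fold higher number from compound 1 to compound 2 (0.30 log units; within the scatter) followed a similar exchange of the group on the sulfonyl sulfur. On that basis, compound 3 is expected to stay close to compound 1, with an expected step of a 1.6-fold higher number from compound 1 to compound 3 (0.21 log units; within the scatter), not beyond the scatter. The estimate for compound 3 in this assay is 10 nM (range 4 nM to 30 nM).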

Compound 3, inhibition constant: 7.7 nM
Compound 3: the middle estimate sits 1.3-fold (0.11 log units) above what was measured, within the range that was stated.
By their numbers in this assay, from the lowest: compounds 1, 3 and 2 (each within the scatter of the next).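

Working notes on the sulfonyl sulfur position: in this assay, replacing the group of compound 1 with 4-acetamidophenyl gives a 1.2-fold higher number from compound 1 to compound 3 (0.09 log units; within the scatter), so on these three compounds the six-membered non-aromatic ring with 2 hetero atoms is not needed for a value in this range. The second direct comparison, acetamido in place of methoxy on an aromatic carbon, gives a 1.6-fold lower number from compound 2 to compound 3 (0.20 log units; within the scatter), so all three compounds now lie within the scatter of the next and these exchanges do not separate them. Nothing further is available to help interpret these steps.

As far as these compounds go, it remains open whether a carboxylic acid or an amine in place of acetamido on the aromatic ring would stay within this narrow spread. From the compounds shown here alone, it is equally open whether a simple methyl group on the sulfonyl sulfur, with no aromatic ring, would do so.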